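Taking the chloro group off compound 3

The source may report more compounds than this note shows. Statements on the series, on what has been measured and on what is new or still open speak of the compounds shown alone.

In a functional assay on MCF7 cells (Homo sapiens) for inhibition, read by CCK-8 assay, with a stated time of 48 h (on this read-out higher numbers stand for weaker inhibition and lower numbers for stronger inhibition), compound 1 `COc1cc(-c2ccnc3cc(-c4cn(CO)c5ccccc45)nn23)cc(OC)c1OC` reads 19 nM and compound 3 `COc1cc(-c2ccnc3cc(-c4ccc(Cl)cc4)nn23)cc(OC)c1OC` reads 2320 nM on the same scale. Compound 3 therefore holds the higher of the two actual numbers, and its gap to compound 1 lies beyond the scatter. For compound 2 `COc1cc(-c2cc3nccc(-c4c[nH]c5ccccc45)n3n2)cc(OC)c1OC` the reading > 10000 nM is a limit and not a number.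

Compound 4 `COc1cc(-c2ccnc3cc(-c4ccccc4)nn23)cc(OC)c1OC` has hydrogen in place of chloro on an aromatic carbon, para to a large group, so that 4-chlorophenyl becomes phenyl hydrogen in place of chloro on an aromatic carbon with the rest of the structure unchanged. For the measured compounds named here, no measured pair shows this change directly, so the expectation starts from compound 3 at 2320 nM and assumes that little moves. The step expected in this assay is estimated as a 1.3-fold higher number from compound 3 to compound 4 (0.11 log units; within the scatter) and would lie within the scatter, with at most a slight drift towards a higher number. Compound 4 is estimated at 3000 nM with an expected range from 800 nM to 10000 nM for the measurement.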

Compound 4, half-maximal inhibitory concentration: 254 nM
For compound 4 the middle estimate is 12-fold (1.07 log units) above the measured one; measured number below the stated range.
By their numbers in this assay, from the lowest: compound 1; then compound 4; then compound 3. At a limit, above all of these: compound 2.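

In this assay, the change from 4-chlorophenyl to phenyl gives a 9.1-fold lower number from compound 3 to compound 4 (0.96 log units; beyond the scatter). This is the first direct reading of a change in one place among these compounds, and it shows that the chloro group, on an aromatic carbon para to a large group, is not needed for inhibition in this series, since the compound without it inhibits more strongly. Nothing shown here bears on why the step runs in this direction.

The compounds shown leave open whether this holds only for chloro, as a fluoro, a methoxy or an amine in the same place could read closer to either compound. This single pair also cannot tell whether removing chloro would have the same effect on another core.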